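This account rests on a few compounds, and the source may have more. Where it says the series, first, only, none or still open, it means among the compounds named here.

The series shares one core: compound 1 `COc1ccc(NC(=O)c2cn(-c3ccccc3)nc2-c2ccccc2)cc1` and compound 2 `COc1ccc(-c2nn(-c3ccccc3)cc2C(=O)Nc2ccc(Br)cc2)cc1`. In a functional assay on HCT-116 cells (Homo sapiens) for cytotoxicity, read by MTT assay, with a stated time of 48 h (a higher number here means a weaker inhibitor, a lower number a stronger inhibitor), compound 1 gives 1350 nM. In this assay compound 2 gives 5870 nM, the highest of the two numbers; compound 1 is its nearest neighbour and sits at a lower number, a gap beyond the scatter. For the measured compounds named here, the two compounds differ in more than one place, so no single step between them can be read. Compound 3 `COc1ccc(NC(=O)c2cn(-c3ccccc3)nc2-c2ccc(OC)cc2)cc1` follows from compound 2 by one change: methoxy in place of bromo on an aromatic carbon. Compound 3 thereby carries the (4-methoxyphenyl)amino group that compound 1 also bears. The step in this assay is expected to run toward a lower number, estimated as a 2.9-fold lower number from compound 2 to compound 3 (0.47 log units; beyond the scatter), with one neighbour only as guidance. Compound 3 in this assay is expected near 2000 nM, within a range from 700 nM to 6000 nM.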

Compound 3, half-maximal inhibitory concentration: 1520 nM
Compound 3: the middle estimate sits 1.3-fold (0.12 log units) above what was measured; the range from low to high includes it.
By their numbers in this assay, from the lowest: compounds 1 and 3 (each within the scatter of the next); then compound 2.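

In this assay the exchange of 4-bromophenyl for 4-methoxyphenyl on the amide nitrogen gives the first step readable at a single place in the series: a 3.9-fold lower number from compound 2 to compound 3 (0.59 log units; beyond the scatter). The second step, which adds a methoxy group to the other aryl group, is a 1.1-fold higher number from compound 1 to compound 3 (0.05 log units; within the scatter), so this added methoxy leaves compound 1 and compound 3 indistinguishable in this read-out. Nothing measured here bears on the reason for either step.

Going by these compounds, both steps rest on one pair each, so it remains open whether the bromo to methoxy step would read the same on the core of compound 1. Also open, on these data alone, is how an amine, a carboxylic acid or a longer alkoxy chain would read at this place on the amide aryl ring.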